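Compound 3 to compound 4: nitro to dimethylamino

The source may report more compounds than this note shows. Statements on the series, on what has been measured and on what is new or still open speak of the compounds shown alone.

In an ADME assay on Raji cells (Homo sapiens) for cytotoxicity, read by luminescence, with a stated time of 72 h (on this read-out higher numbers stand for an effect only at larger amounts of compound and lower numbers for an effect already at smaller amounts), compound 1 `CCOC(=O)c1c(-c2cc(F)cc(OC)c2)[nH]c2cc(OC)ccc2c1=O` gives > 21500 nM, which is a limit of the assay and not a number. Compound 2 `CCOC(=O)c1c(-c2cccc(C)c2)[nH]c2cc(OC)ccc2c1=O` also gives only a limit, > 21500 nM. Compound 3 `CCOC(=O)c1c(-c2cccc([N+](=O)[O-])c2)[nH]c2cc(OC)ccc2c1=O` likewise gives only a limit, > 21500 nM, so it stands with the other two and cannot be ranked against them. For the measured compounds named here, the series so far reads as the limit of > 21500 nM in this assay, at which 3 of the 3 values shown sit.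

The next change leads to compound 4 `CCOC(=O)c1c(-c2cccc(N(C)C)c2)[nH]c2cc(OC)ccc2c1=O`, with dimethylamino in place of nitro on an aromatic carbon, meta to a large group: dimethylamino in place of nitro on an aromatic carbon.

The measured steps that bear on this change are a step that the two limits leave unreadable from compound 2 to compound 3, a step that the two limits leave unreadable from compound 1 to compound 3 and a step that the two limits leave unreadable from compound 1 to compound 2. None of them has a size that can be carried over. With a step that the two limits leave unreadable from compound 2 to compound 3 as the closest guide for compound 3, no step beyond the scatter is expected in this assay, and no direction can be given. The estimated move is a step that the limit leaves unreadable from compound 3 to compound 4, and another limit is the expected report. Compound 4 is estimated at 25000 nM, with an expected range of 9000 nM to 45000 nM.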

Compound 4, half-maximal effective concentration: > 21500 nM
Compound 4: only a limit was reported; the forecaster's own chance of this, stated with the estimate: 75%; the middle value lies beyond the limit too.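

No new step can be read: compound 4, like compound 1, compound 2 and compound 3, gives only a limit, and the series stands at one reading: the limit of > 21500 nM in this assay, at which 4 of the 4 values shown sit.

The compounds shown leave open whether any change on this phenyl group gives a readable value, and how the four compounds rank.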